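A few compounds are considered here, and "the series" means these few. Any claim that something is new, unique, unknown or untested is made for them only; others in the source may bear on it.

Compound 3 `CC1CC(=O)N(C(C)C(=O)NCc2cccc(Cl)c2)C1=O` gives 90.3 mg/kg in a functional assay on the whole organism (strain Albino Swiss CD1) with Mus musculus as the target, in the maximal electroshock model; on this read-out lower numbers stand for an effect already at smaller amounts and higher numbers for an effect only at larger amounts of compound; this is the highest of the three numbers on record, though compound 2 `CC1CC(=O)N(C(C)C(=O)NCc2ccccc2Cl)C1=O` with 85.9 mg/kg and compound 1 `CC(C(=O)NCc1cccc(F)c1)N1C(=O)CCC1=O` with 77.4 mg/kg both lie within the scatter of it. Compound 4 `CC1CC(=O)N(C(C)C(=O)NCc2cccc(F)c2)C1=O` differs from compound 3 by fluoro in place of chloro on an aromatic carbon. No measured step tracks this exchange: the single step shown, a 1.1-fold higher number from compound 2 to compound 3 (0.02 log units; within the scatter), shifts the position of the chloro rather than replacing it, and compound 1, which carries the fluoro, differs from compound 3 in a second place as well, so its value against compound 3 shows only that the two fall within the scatter. The step of a 1.1-fold lower number from compound 3 to compound 4 (0.04 log units; within the scatter) is therefore expected to stay within the scatter. Compound 4 is expected to give 82 mg/kg, between 45 mg/kg and 150 mg/kg.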

Compound 4, dose for half-maximal effect: 130 mg/kg
Compound 4: the middle estimate sits 1.6-fold (0.20 log units) below what was measured; the range from low to high includes it.
By their numbers in this assay, from the lowest: compounds 1, 2, 3 and 4 (each within the scatter of the next).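

In this assay the exchange of chloro for fluoro, on an aromatic carbon meta to a large group, gives a 1.4-fold higher number from compound 3 to compound 4 (0.16 log units; within the scatter) and so puts a direct reading on this change, which stays within the scatter. 3-Fluorophenyl in place of 2-chlorophenyl gives a 1.5-fold higher number from compound 2 to compound 4 (0.18 log units; within the scatter) and methyl in place of hydrogen on a saturated ring carbon gives a 1.7-fold higher number from compound 1 to compound 4 (0.23 log units; within the scatter) and both of these also stay within the scatter. Nothing measured here bears on why these steps come out as they do. The compounds shown leave open whether a methoxy or a trifluoromethyl group at this place would move the number beyond the scatter.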